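Swapping bromo for hexyloxy on a sulfonamide core

The source may hold more compounds than are shown below. What is called first, only, known or untested is meant among the compounds shown, and "the series" means these compounds.

Compound 3 `O=C1NCCN1c1ccc(S(=O)(=O)Nc2ccc(Br)cc2)cc1` gives the lowest of the two numbers seen in a functional assay on HT-29 cells (Homo sapiens) for antiproliferative activity, read by sulforhodamine B assay, with a stated time of 48 h (a higher number here means a weaker inhibitor, a lower number a stronger inhibitor), at 300 nM. Its nearest neighbour is compound 1 `COc1ccc(NS(=O)(=O)c2ccc(N3CCNC3=O)cc2)cc1`, which in this assay gives 800 nM, so that a 2.7-fold lower number from compound 1 to compound 3 (0.43 log units; beyond the scatter). Compound 2 `O=C1NCCN1c1ccc(S(=O)(=O)Nc2ccc(C3CCCCC3)cc2)cc1` sits only at a limit of this assay, reported as > 1000 nM. That limit means an at least 3.3-fold lower number from compound 2 to compound 3 (0.52 log units; beyond the scatter), and an at least 1.2-fold higher number from compound 1 to compound 2 (0.09 log units; that floor lies within the scatter).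

Compound 4 `CCCCCCOc1ccc(NS(=O)(=O)c2ccc(N3CCNC3=O)cc2)cc1` differs from compound 3 in one place: hexyloxy in place of bromo on an aromatic carbon. For the measured compounds named here, two measured steps bear on this change. Methoxy, the other oxygen-linked group, gave a modest rise from compound 3 to compound 1, and cyclohexyl gave a rise of at least the same order into the limit of compound 2. Hexyloxy is expected to behave more like those two than like bromo, so the number for compound 4 is expected to rise beyond the scatter, with a 4.0-fold higher number from compound 3 to compound 4 (0.60 log units; beyond the scatter) as the estimated step. For compound 4 the estimate in this assay is 1200 nM, between 400 nM and 4000 nM.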

Compound 4, half-maximal inhibitory concentration: > 1000 nM
Compound 4 ended at the assay's limit (the forecaster's own chance of this, stated with the estimate: 50%); the middle value lies beyond the limit too.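

Bromo is still the only group shown at this place, on an aromatic carbon para to a large group, that gives a number below the limit or the value of its neighbours: hexyloxy in place of bromo gives an at least 3.3-fold higher number from compound 3 to compound 4 (0.52 log units; beyond the scatter) in this assay, so methoxy, cyclohexyl and hexyloxy all sit higher than bromo. Extending the methoxy of compound 1 with pentyl gives an at least 1.2-fold higher number from compound 1 to compound 4 (0.09 log units; that floor lies within the scatter), and since that floor lies within the scatter, a longer chain is not shown to add to the loss. The value of compound 4 is a limit, and the step between compound 2 and compound 4 cannot be read because both values are limits: the limit of > 1000 nM in this assay, at which 2 of the 4 values shown sit.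

On these data alone, whether chloro or an amine at this place would match bromo remains open. So does how far hexyloxy and cyclohexyl actually lie beyond the limit.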